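Hydrazide variations on a sulfonyl indole carboxamide core

The source may report more compounds than this note shows. Statements on the series, on what has been measured and on what is new or still open speak of the compounds shown alone.

The series shares one core, shown by compound 1, `Cc1cc(C)cc(S(=O)(=O)c2c(C(=O)NCC(N)=O)[nH]c3ccc(Cl)cc23)c1`. In a functional assay on C8166 cells (Homo sapiens) for antiproliferative activity, read by MTT assay (a higher number here means that more compound is tolerated, a lower number that less compound is tolerated), compound 1 gives > 100 uM, which is a limit of the assay and not a number. Compound 2, `Cc1cc(C)cc(S(=O)(=O)c2c(C(=O)NCC(=O)NN)[nH]c3ccc(Cl)cc23)c1`, differs by amino in place of hydrogen on an amide-type nitrogen; in this assay compound 2 gives > 100 uM, again a limit. Compound 3, `CCOC(=O)NNC(=O)c1[nH]c2ccc(Cl)cc2c1S(=O)(=O)c1cc(C)cc(C)c1`, carries (ethoxycarbonyl)amino in place of carbamoylmethyl on an amide-type nitrogen; in this assay compound 3 gives > 100 uM, also a limit. The measured steps are a step that the two limits leave unreadable from compound 1 to compound 2, a step that the two limits leave unreadable from compound 1 to compound 3 and a step that the two limits leave unreadable from compound 2 to compound 3; none of them has a readable size because of the limit of > 100 uM in this assay, at which 3 of the 3 values shown sit.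

Compound 4, `Cc1cc(C)cc(S(=O)(=O)c2c(C(=O)NNC(=O)NN)[nH]c3ccc(Cl)cc23)c1`, follows from compound 1 by (aminocarbamoyl)amino in place of carbamoylmethyl on an amide-type nitrogen. For the measured compounds named here, the steps that bear on it, the replacement of the same group in compound 3 and the added nitrogen on that position in compound 2, give no readable size and no direction for this assay. In this assay the step from compound 1 is therefore expected to be a step that the limit leaves unreadable from compound 1 to compound 4, nothing beyond the scatter, with compound 4 expected to remain at the limit. Compound 4 is estimated at 150 uM, within 60 uM to 400 uM.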

Compound 4, half-maximal toxic concentration: > 100 uM
Compound 4 ended at the assay's limit; the forecaster's own chance of this, stated with the estimate: 85%; the middle value does not contradict the limit.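

No step among compound 1, compound 2, compound 3 and compound 4 can be read in this assay, because each value is a limit of the assay and not a number: the limit of > 100 uM in this assay, at which 4 of the 4 values shown sit.

The compounds shown leave open whether the groups carried on the amide-type nitrogen differ at all in this assay.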